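One Trifluoromethyl Removed From Two Ureas That Show Nothing

The compounds below may be only part of what the source reports. "The series", "measured", "known", "first", "only" and "open" are said of these compounds alone.

Measured in a functional assay on OVCAR-3 cells (Homo sapiens) for inhibition, read by sulforhodamine B assay, with a stated time of 48 h, tested at 0.01 uM; on this read-out higher numbers stand for a weaker effect at the one concentration tested and lower numbers for a stronger effect:
compound 1 `O=C(Nc1cccc(-n2cc(-c3ccncc3)c(-c3cc(O)cc(Cl)c3)n2)c1)Nc1ccc(Cl)c(C(F)(F)F)c1` gives 101%
compound 2 `COc1cc(Cl)cc(-c2nn(-c3cccc(NC(=O)Nc4cc(C(F)(F)F)cc(C(F)(F)F)c4)c3)cc2-c2ccncc2)c1` gives 105%

Both compounds share a core carrying a urea that links to an aromatic ring bearing trifluoromethyl, and in this assay both read as essentially untouched cells at the single concentration tested. Compound 2 gives the higher of the two figures, but the gap to compound 1 lies within the usual scatter, so the two compounds cannot be told apart on these numbers. Going by the values given here, no pair of measured compounds differs in just one place, so no single structural step has been followed yet.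

Among the compounds with values here, compound 3 `COc1cc(Cl)cc(-c2nn(-c3cccc(NC(=O)Nc4cccc(C(F)(F)F)c4)c3)cc2-c2ccncc2)c1` is the first such step. It differs from compound 2 only by hydrogen in place of trifluoromethyl on an aromatic carbon. Nothing measured here connects a change of this kind to a change in the read-out, and compound 2 itself shows no effect to lose. The expectation for this assay is therefore no step beyond the scatter, a move of about a number 3 percentage points lower from compound 2 to compound 3 (within the scatter) from compound 2. Compound 3 is estimated at 102%, within 90% to 113%.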

Compound 3, a percentage reported as activity, at one concentration (the size of the read-out at that concentration, not a potency): 100%
Compound 3: middle estimate off by 2 percentage points, on the high side; the range from low to high includes it.
By their numbers in this assay, from the lowest: compounds 3, 1 and 2 (each within the scatter of the next).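

In this assay, going by these compounds alone, putting hydrogen in place of trifluoromethyl on this aromatic carbon gives a number 5 percentage points lower from compound 2 to compound 3 (within the scatter), the first direct look at this one position, and the read-out does not shift beyond normal variation. Compound 2 carries two trifluoromethyl groups on that ring and compound 3 keeps one, yet both still read as essentially untouched cells, so at this single concentration the second group makes no visible difference; with no effect present at either end of the step, this cannot show whether the group would matter to a compound that has an effect. Nothing measured on these compounds explains the result.

Going by these compounds, it remains open whether a different group on the same aromatic carbon, such as an amine, a carboxylic acid or a longer carbon chain, would move the read-out away from the level of untouched cells. On these data alone, it is also open whether compound 2 and compound 3 would separate at a higher concentration, where an effect might first appear.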